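The source may hold more compounds than are shown below. What is called first, only, known or untested is meant among the compounds shown, and "the series" means these compounds.

Compound 1 `CCCCOc1ccc(C(=O)/C=C/c2c(/C=C/c3ccc(OC)cc3)cc(OC)cc2OC)cc1` was tested in a functional assay on B16-F10 cells (Mus musculus) for antiproliferative activity, read by MTT assay, with a stated time of 48 h (a lower number here means a stronger inhibitor, a higher number a weaker inhibitor), where compound 1 gives 5.3 ug/mL. For the measured compounds named here, of the two compounds measured so far, this is the higher of the two numbers. Its neighbour, compound 2 `COc1ccc(/C=C/c2cc(OC)cc(OC)c2/C=C/C(=O)c2ccc(N)cc2)cc1`, gives 2.8 ug/mL in this assay, and the change from one to the other is an amino group in place of a butoxy group on an aromatic carbon, a step of a 1.9-fold lower number from compound 1 to compound 2 (0.28 log units; within the scatter).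

Compound 3 `CCOc1ccc(C(=O)/C=C/c2c(/C=C/c3ccc(OC)cc3)cc(OC)cc2OC)cc1` has not yet been measured. It differs from compound 1 in one place: hydrogen in place of ethyl on a saturated chain carbon, two bonds along the chain from an oxygen on an aromatic ring. Going by the values given here, no measured step shortens the butoxy chain in this way, so the only comparison available, that from compound 1 to compound 2, changes a different part of the molecule and offers no direct guide. With nothing to suggest a shift, compound 3 is expected to sit near compound 1, a step of a 1.1-fold lower number from compound 1 to compound 3 (0.03 log units; within the scatter) at most within the scatter. The estimate for compound 3 is therefore 5 ug/mL, with a likely range from 2.5 ug/mL to 10 ug/mL.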

Compound 3, half-maximal inhibitory concentration: 6.4 ug/mL
Estimate against measurement, compound 3: 1.3-fold (0.11 log units) below, and the stated range covers the measured number.
By their numbers in this assay, from the lowest: compounds 2, 1 and 3 (each within the scatter of the next, the first and the last beyond it).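

Shortening the butoxy chain to ethoxy leaves the number in this assay essentially unmoved (a 1.2-fold higher number from compound 1 to compound 3 (0.08 log units; within the scatter)), so across these two compounds the length of this chain makes no readable difference. Ethoxy in place of amino on the aromatic carbon gives the first step here that clears the scatter, though only modestly (a 2.3-fold higher number from compound 2 to compound 3 (0.36 log units; beyond the scatter)), and because compound 1 stays within the scatter of both, this gap does not cleanly separate the two ether chains from amino. No information is available to explain these numbers.

On these data alone, two chain lengths cannot show a trend, so it remains open how a methoxy group or a longer chain such as hexyloxy would compare. A hydroxyl or a dimethylamino group on the same aromatic carbon could also show whether the gap between compound 2 and compound 3 holds up.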